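The compounds below may be only part of what the source reports. "The series", "measured", "known", "first", "only" and "open" are said of these compounds alone.

Measured in a functional assay on HCT-116 cells (Homo sapiens) for inhibition, read by colorimetric assay, with a stated time of 3 days; on this read-out lower numbers stand for stronger inhibition and higher numbers for weaker inhibition:
compound 1 `CC(=O)c1ccc(NC(=O)CCCCCCNC(=O)C(O)(O)C(F)(F)F)cc1`: 12100 nM
compound 2 `O=C(CCCCCCNC(=O)C(O)(O)C(F)(F)F)Nc1nccs1`: 10800 nM

Going by the values given here, on these numbers, compound 2 cannot be separated from compound 1, the only other compound measured. Next in the series is compound 3 `O=C(CCCCCCNC(=O)C(O)(O)C(F)(F)F)Nc1ccc(F)cc1`, and the change is 4-fluorophenyl in place of 1,3-thiazol-2-yl on an amide-type nitrogen. In short, 4-fluorophenyl stands in place of 1,3-thiazol-2-yl on an amide-type nitrogen. Among the compounds with values here, one measured step bears on this change, as it swaps 4-acetylphenyl for 1,3-thiazol-2-yl at the same place: a 1.1-fold lower number from compound 1 to compound 2 (0.05 log units; within the scatter). Within the data shown here, that single step is thin evidence, and no 4-fluorophenyl compound has been measured yet. Even so, no shift beyond the scatter is expected in this assay, so neither direction is favoured. The expected result is a 1.0-fold higher number from compound 2 to compound 3 (0.01 log units; within the scatter). For compound 3 the estimated value is 11000 nM, with an expected range of 5000 nM to 24000 nM.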

Compound 3, half-maximal inhibitory concentration: 7570 nM
Compound 3: middle estimate off by 1.5-fold (0.16 log units), on the high side, within the range that was stated.
By their numbers in this assay, from the lowest: compounds 3, 2 and 1 (each within the scatter of the next).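

In this assay, the step to 4-fluorophenyl stays within the scatter (a 1.4-fold lower number from compound 2 to compound 3 (0.15 log units; within the scatter)), so a six-membered aromatic ring of carbon only cannot be separated from the five-membered ring with two hetero atoms at this amide-type nitrogen. The comparison of fluoro with acetyl on an aromatic carbon also stays within the scatter (a 1.6-fold lower number from compound 1 to compound 3 (0.20 log units; within the scatter)), and all three groups at this place now read alike, with no order among them. Nothing available explains these small differences.

Going by these compounds, it remains open whether any group at this place can move the number beyond the scatter, for example an amine or a carboxylic acid on the aromatic ring. On these data alone, how a longer chain in the shared core would read is also open.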